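The source may hold more compounds than are shown below. What is called first, only, known or untested is meant among the compounds shown, and "the series" means these compounds.

Working notes on the series.

Three amides of the shared core have been run in a functional assay on the whole organism (strain Wistar) for inhibition, with Rattus norvegicus as the target, read by paw edema, with stated times of 60 min and 6 h, at a dose of 100 mg/kg by the oral route; on this read-out higher numbers stand for more inhibition at the one dose given (going by the name of the read-out) and lower numbers for less inhibition. Compound 1 `CNC(=O)CC1CCc2cc(OC)c(OC)cc21` gives 24.1%. Compound 2 `CCCNC(=O)CC1CCc2cc(OC)c(OC)cc21` gives 22.2%, a result that, as shown by a number 1.9 percentage points lower from compound 1 to compound 2 (within the scatter), does not separate the two. Going by the values given here, compound 3 `COc1cc2c(cc1OC)C(CC(=O)NC1CCCC1)CC2` gives 40.7% and stands highest of the three, with the steps of a number 16.6 percentage points higher from compound 1 to compound 3 (beyond the scatter) and a number 18.5 percentage points higher from compound 2 to compound 3 (beyond the scatter) both lying beyond the scatter; on these numbers the cyclopentyl on the amide-type nitrogen is the one change so far that has moved the read-out.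

Compound 4 `COc1cc2c(cc1OC)C(CC(=O)N1CCOCC1)CC2` is not yet measured in this assay. It differs from compound 3 in one place: morpholin-4-yl in place of cyclopentylamino on a carbonyl carbon. The steps measured so far concern only the substituent carried by the amide-type nitrogen while that nitrogen keeps its hydrogen; none of them covers the loss of the hydrogen-bond donor and the entry of a ring with a hetero atom that is counted here. The gain seen on going to compound 3 may therefore not carry over, and the expectation is for compound 4 to fall back toward the level of compound 1 and compound 2, a step of a number 12.7 percentage points lower from compound 3 to compound 4 (beyond the scatter) that is estimated, not measured. Compound 4 is expected to give about 28% in this assay, within a range of 12% to 45%.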

Compound 4, a percentage reported as inhibition, in the whole organism at one dose (the size of the read-out at that dose, not a potency): 14.8%
The estimate for compound 4 lay 13.2 percentage points above the measured number, within the range that was stated.
By their numbers in this assay, from the lowest: compounds 4, 2 and 1 (each within the scatter of the next); then compound 3.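

In this assay, a ring on the carbonyl carbon does not in itself hold the number up: morpholin-4-yl in place of cyclopentylamino gives a number 25.9 percentage points lower from compound 3 to compound 4 (beyond the scatter), so the gain seen with compound 3 belongs to cyclopentylamino and not to every ring at this place. Against the two open-chain amides, the change gives a number 7.4 percentage points lower from compound 2 to compound 4 (within the scatter) and a number 9.3 percentage points lower from compound 1 to compound 4 (within the scatter), which leaves compound 4 not separated from compound 1 or compound 2, and compound 3 as the only amide at this place that stands apart. No measurement on hand says why morpholin-4-yl and cyclopentylamino differ.

Morpholin-4-yl differs from cyclopentylamino in more than one respect, with no hydrogen-bond donor, a hydrogen-bond acceptor and a six-membered ring with hetero atoms, and the compounds shown do not tell these apart. On these data alone, whether the drop follows the loss of the amide hydrogen, the ring oxygen or the ring size stays open; piperidin-1-yl would keep the six-membered ring without the oxygen, and cyclohexylamino would keep the amide hydrogen with a six-membered ring of carbon only.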